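This account rests on a few compounds, and the source may have more. Where it says the series, first, only, none or still open, it means among the compounds named here.

Of the compounds shown here, three sharing one core have been measured in an ADME assay on a cell-free system (plasma, Homo sapiens) for metabolic stability, read by LC-MS; on this read-out lower numbers stand for a shorter-lived compound and higher numbers for a longer-lived compound. Compound 1 `CCCCOC(=O)c1cccc(-c2cc(C(=O)Nc3ccncc3)ccc2CN)c1`, a butyl ester, gives 0.367 h. Compound 2 `CCCCCCOC(=O)c1cccc(-c2cc(C(=O)Nc3ccncc3)ccc2CN)c1`, a hexyl ester, gives 0.833 h. Compound 3 `NCc1ccc(C(=O)Nc2ccncc2)cc1-c1cccc(C(=O)OCc2ccccc2)c1`, a benzyl ester, gives 1.07 h. Compound 3 therefore stands level with compound 2 and clear of compound 1. The data show a 1.3-fold higher number from compound 2 to compound 3 (0.11 log units; within the scatter), and also a 2.9-fold higher number from compound 1 to compound 3 (0.46 log units; beyond the scatter). The longer chain alone also made a difference, with a 2.3-fold higher number from compound 1 to compound 2 (0.36 log units; beyond the scatter).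

The next compound is compound 4 `NCc1ccc(C(=O)Nc2ccncc2)cc1-c1cccc(C(=O)OCC2CCCC2)c1`, and the change that produces it is cyclopentyl in place of phenyl on a saturated chain carbon bound to an oxygen next to a carbonyl group. In words, cyclopentyl takes the place of phenyl on a saturated chain carbon bound to an oxygen next to a carbonyl group, so benzyl becomes cyclopentylmethyl.

No cyclopentyl ester has been measured, so the guide is indirect. The closest comparison is the exchange of pentyl for phenyl at this same place, which gave a 1.3-fold higher number from compound 2 to compound 3 (0.11 log units; within the scatter). Only compound 1, with its shorter chain, stands apart from the other two. A step within the scatter is therefore expected in this assay, with no firm direction, though a larger move cannot be excluded. The expected change is a 1.3-fold lower number from compound 3 to compound 4 (0.13 log units; within the scatter). For compound 4 the estimated half-life is 0.8 h, with an expected range of 0.4 h to 1.6 h.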

Compound 4, half-life: 0.517 h
Estimate against measurement, compound 4: 1.5-fold (0.19 log units) above, within the range that was stated.
By their numbers in this assay, from the lowest: compounds 1, 4, 2 and 3 (each within the scatter of the next, the first and the last beyond it).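

In this assay, for the compounds shown here, the earlier compounds left it unclear whether the ester group could be changed at this place without much effect on the number, as the exchange of pentyl for phenyl gave only a 1.3-fold higher number from compound 2 to compound 3 (0.11 log units; within the scatter) and stayed within the scatter. Replacing one ring with another does register: cyclopentyl in place of phenyl gives a 2.1-fold lower number from compound 3 to compound 4 (0.32 log units; beyond the scatter), which is beyond the scatter. Compound 4 also stands level with both straight-chain esters, with a 1.6-fold lower number from compound 2 to compound 4 (0.21 log units; within the scatter) and a 1.4-fold higher number from compound 1 to compound 4 (0.15 log units; within the scatter), although those two esters are themselves separated by a step beyond the scatter. A ring at this place therefore does not by itself go with the higher number, and nothing measured here tells why the two rings part.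

The compounds shown leave open where a cyclohexylmethyl or a pyridylmethyl ester would fall, and whether a branched chain such as isopropyl would stand with the butyl and hexyl esters. They also leave open how an amide in place of the ester would behave in this assay on the same core.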